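Bromo in place of hydrogen: cytotoxicity of compound 4

A few compounds are considered here, and "the series" means these few. Any claim that something is new, unique, unknown or untested is made for them only; others in the source may bear on it.

Measured compounds:
- compound 1, `COC(=O)c1ccc(NCc2cncn2Cc2ccccc2)cc1-c1ccccc1`: > 1000 nM (a limit)
- compound 2, `CCC(=O)c1ccc(NCc2cncn2Cc2ccc(-c3ccccc3)cc2)cc1-c1ccccc1`: > 10000 nM (a limit)
- compound 3, `Cc1ccccc1-c1cccc(NCc2cncn2Cc2ccccc2)c1`: > 1000 nM (a limit)

In a toxicity assay on NIH3T3 cells (Mus musculus) for cytotoxicity, read by resazurin assay (on this read-out lower numbers stand for an effect already at smaller amounts and higher numbers for an effect only at larger amounts of compound), compound 1 gives > 1000 nM, which is a limit of this assay and not a number. The same is true of compound 2, whose value of > 10000 nM is also a limit. Compound 3, at > 1000 nM, likewise sits at a limit. Compound 1 therefore stands with two of the three values shown at the limit of > 1000 nM in this assay, at which 2 of the 3 values shown sit, while the remaining value sits at the limit of > 10000 nM in this assay, at which 1 of the 3 values shown sits. None of the three compounds shows cytotoxicity within the range of this assay.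

Compound 4, `COC(=O)c1ccc(NCc2cncn2Cc2ccccc2Br)cc1-c1ccccc1`, differs from compound 1 by bromo in place of hydrogen on an aromatic carbon, on an aromatic carbon of a six-membered aromatic ring of carbon only. No step between measured compounds is shown for this assay, so there is no measured guide to its size. A change of this kind is expected to stay within the usual scatter, with no direction beyond it. Compound 4 is expected to give about 3000 nM, with a range from 1000 nM to 10000 nM. The expected step that the limit leaves unreadable from compound 1 to compound 4 is estimated to lie within the scatter, and a limit rather than a number is likely.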

Compound 4, half-maximal effective concentration: 10000 nM
The estimate for compound 4 lay 3.3-fold (0.52 log units) below the measured number, within the range that was stated.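

In this assay compound 1 gives > 1000 nM, which is a limit and not a number, so the step from compound 1 to compound 4 cannot be read. The compounds shown leave open whether bromo in place of hydrogen changes cytotoxicity at all, and in which direction.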